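Amide and ethenyl changes at one position of a shared core

The source may hold more compounds than are shown below. What is called first, only, known or untested is meant among the compounds shown, and "the series" means these compounds.

Growth inhibition measured in a functional assay on PC-3 cells (Homo sapiens) for inhibition, read by sulforhodamine B assay, with a stated time of 72 h; a lower number here means a stronger inhibitor of growth, a higher number a weaker inhibitor of growth:
compound 1 `COc1ncc(-c2ccc3nccc(/C(C)=C/C(=O)N(C)CCO)c3c2)cc1NS(=O)(=O)c1ccc(F)cc1F`: 290 nM
compound 2 `COc1ncc(-c2ccc3nccc(/C(C)=C/C(=O)N4CCN(C)CC4)c3c2)cc1NS(=O)(=O)c1ccc(F)cc1F`: 360 nM
compound 3 `COc1ncc(-c2ccc3nccc(/C=C/C(=O)N4CCN(C)CC4)c3c2)cc1NS(=O)(=O)c1ccc(F)cc1F`: 450 nM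

Compound 3 cannot be separated from the other two, as a 1.6-fold higher number from compound 1 to compound 3 (0.19 log units; within the scatter) and a 1.3-fold higher number from compound 2 to compound 3 (0.10 log units; within the scatter) both lie within the scatter. Compound 4 `COc1ncc(-c2ccc3nccc(/C(C)=C/C(=O)N4CCCC4)c3c2)cc1NS(=O)(=O)c1ccc(F)cc1F` carries 1-methyl-2-((pyrrolidin-1-yl)carbonyl)ethenyl in place of 2-((4-methylpiperazin-1-yl)carbonyl)ethenyl on an aromatic carbon. Going by the values given here, two measured steps bear on this change. The step on the 1-methyl is a 1.3-fold higher number from compound 2 to compound 3 (0.10 log units; within the scatter), and the step on the amide is a 1.2-fold higher number from compound 1 to compound 2 (0.09 log units; within the scatter). Among the compounds with values here, both stayed within the scatter, though no compound with the pyrrolidin-1-yl group has been measured. No shift beyond the scatter is therefore expected in this assay. The expected change is a 1.3-fold lower number from compound 3 to compound 4 (0.11 log units; within the scatter). For compound 4 the estimated value is 350 nM, with an expected range from 150 nM to 800 nM.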

Compound 4, concentration for 50% growth inhibition: 1160 nM
Compound 4: middle estimate off by 3.3-fold (0.52 log units), on the low side, and the stated range ends below it.
By their numbers in this assay, from the lowest: compounds 1, 2 and 3 (each within the scatter of the next); then compound 4.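

In this assay, going by these compounds alone, the amide on this ethenyl group proves able to shift growth inhibition: pyrrolidin-1-yl on the carbonyl carbon gives a 3.2-fold higher number from compound 2 to compound 4 (0.51 log units; beyond the scatter) against 4-methylpiperazin-1-yl and a 4.0-fold higher number from compound 1 to compound 4 (0.60 log units; beyond the scatter) against (2-hydroxyethyl)(methyl)amino, whereas every step among the earlier compounds stayed within the scatter. With the 1-methyl also changing, the step is a 2.6-fold higher number from compound 3 to compound 4 (0.41 log units; beyond the scatter). Nothing available here explains these steps.

On these data alone, whether a piperidine or morpholine amide, or an open-chain dimethylamino amide, would behave like pyrrolidin-1-yl remains open. So does the effect of pyrrolidin-1-yl on the ethenyl without the 1-methyl.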